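The compounds below may be only part of what the source reports. "The series", "measured", "known", "first", "only" and "open" are said of these compounds alone.

Measured in an ADME assay on NIH3T3 cells (Mus musculus) for cytotoxicity, read by MTT assay, with a stated time of 24 h; a higher number here means a weaker inhibitor, a lower number a stronger inhibitor:
compound 1 `Cn1cnnc1SCC(=O)N/N=c1/scc(-c2ccc([N+](=O)[O-])cc2)n1-c1ccccc1`, 133 ug/mL
compound 2 `O=C(CSc1ncccn1)N/N=c1/scc(-c2ccc([N+](=O)[O-])cc2)n1-c1ccccc1`, 193 ug/mL
compound 3 `Cn1cnnc1SCC(=O)N/N=c1/scc(-c2ccc(Cl)cc2)n1-c1ccccc1`, 51.7 ug/mL

Compound 4 `O=C(CSc1ncccn1)N/N=c1/scc(-c2ccc(Cl)cc2)n1-c1ccccc1` has not yet been measured in this assay. It shares its core with compound 3, and that core differs from the core of compound 1 by chloro in place of nitro on an aromatic carbon, a change that gave a 2.6-fold lower number from compound 1 to compound 3 (0.41 log units; beyond the scatter). The change from compound 3 to compound 4 is pyrimidin-2-yl in place of 4-methyl-4H-1,2,4-triazol-3-yl on a sulfur. The same change has been made once before, from compound 1 to compound 2, where it gave a 1.5-fold higher number from compound 1 to compound 2 (0.16 log units; within the scatter). The surroundings of the changed sulfur read the same in both pairs, so this is the same change carried onto a different core. For the measured compounds named here, only that one earlier example is available, and the expectation rests on it alone. Because the earlier step of a 1.5-fold higher number from compound 1 to compound 2 (0.16 log units; within the scatter) was small, compound 4 is expected to move by about a 1.5-fold higher number from compound 3 to compound 4 (0.16 log units; within the scatter). Compound 4 is estimated at 75 ug/mL, with a likely range from 40 ug/mL to 150 ug/mL.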

Compound 4, half-maximal inhibitory concentration: 397 ug/mL
Estimate against measurement, compound 4: 5.3-fold (0.72 log units) below; the measured number lies above the stated range.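

In this assay, pyrimidin-2-yl in place of 4-methyl-4H-1,2,4-triazol-3-yl on a sulfur gave a 7.7-fold higher number from compound 3 to compound 4 (0.89 log units; beyond the scatter), so the small step seen on the core of compound 1 did not carry over to the core of compound 3: the same change on two cores in this assay, a 1.5-fold higher number (0.16 log units; within the scatter) from compound 1 to compound 2 and a 7.7-fold higher number (0.89 log units; beyond the scatter) from compound 3 to compound 4, 5.3-fold (0.72 log units) apart, beyond the scatter of two such steps. Read the other way round, chloro in place of nitro on an aromatic carbon gave a 2.1-fold higher number from compound 2 to compound 4 (0.31 log units; beyond the scatter), so this change moved the number in the opposite direction once pyrimidin-2-yl was present: the same change on two cores in this assay, a 2.6-fold lower number (0.41 log units; beyond the scatter) from compound 1 to compound 3 and a 2.1-fold higher number (0.31 log units; beyond the scatter) from compound 2 to compound 4, 5.3-fold (0.72 log units) apart, beyond the scatter of two such steps. In these four compounds, then, the size of a change at one place depends on the group at the other, but this does not show why, and a single pair on each core cannot show how general this is.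

From the compounds shown here alone, it remains open whether the same dependence appears with other groups on the aromatic carbon, such as methoxy or fluoro. Going by these compounds, it is also open whether a pyridin-2-yl ring or a simple alkyl chain on the sulfur would follow compound 3 or compound 4.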